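This account rests on a few compounds, and the source may have more. Where it says the series, first, only, none or still open, it means among the compounds named here.

Compound 1 `CCc1ccc2nc(C(=O)Nc3c(F)cc(-c4cccc(F)c4)cc3F)c(C)c(C(=O)O)c2c1`, compound 2 `Cc1c(C(=O)Nc2c(F)cc(-c3cccc(F)c3)cc2F)nc2ccc(F)cc2c1C(=O)O` and compound 3 `CCOc1ccc2nc(C(=O)Nc3c(F)cc(-c4cccc(F)c4)cc3F)c(C)c(C(=O)O)c2c1` were measured; in a functional assay on A-375 cells (Homo sapiens) for antiproliferative activity, read by MTT assay, with a stated time of 24 h, tested at 100 ug/mL (a lower number here means a weaker effect, a higher number a stronger effect of the compound at the concentration tested), compound 1 gives 71.3%, compound 2 gives 64.3% and compound 3 gives 72.4%.

Compound 3 holds the highest of the three numbers, yet the steps of a number 1.1 percentage points higher from compound 1 to compound 3 (within the scatter) and a number 8.1 percentage points higher from compound 2 to compound 3 (within the scatter) show that the three compounds are not separated from one another. Compound 4 `COc1ccc2nc(C(=O)Nc3c(F)cc(-c4cccc(F)c4)cc3F)c(C)c(C(=O)O)c2c1` differs from compound 3 by hydrogen in place of methyl on a saturated chain carbon bound to an oxygen on an aromatic ring. The two steps that touch the same aromatic carbon, a number 1.1 percentage points higher from compound 1 to compound 3 (within the scatter) and a number 8.1 percentage points higher from compound 2 to compound 3 (within the scatter), both stayed within the scatter, so the change to compound 4 is expected to bring no step beyond the scatter in this assay either. Compound 4 is therefore estimated to give 70% (range 58% to 80%), an expected step of a number 2.4 percentage points lower from compound 3 to compound 4 (within the scatter).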

Compound 4, a percentage reported as inhibition, at one concentration (the size of the read-out at that concentration, not a potency): 58.7%
Estimate against measurement, compound 4: 11.3 percentage points above; the measured number falls inside the stated range.
By their numbers in this assay, from the lowest: compounds 4, 2, 1 and 3 (each within the scatter of the next, the first and the last beyond it).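

In this assay, for the compounds shown here, the change from ethoxy to methoxy on this aromatic carbon gives a number 13.7 percentage points lower from compound 3 to compound 4 (beyond the scatter) and so, unlike the earlier steps here, passes the scatter. Methoxy in place of ethyl likewise gives a number 12.6 percentage points lower from compound 1 to compound 4 (beyond the scatter) while methoxy in place of fluoro gives a number 5.6 percentage points lower from compound 2 to compound 4 (within the scatter) and leaves compound 2 separated from neither end of the series. Nothing measured here accounts for these steps.

On these data alone, whether a longer chain such as propoxy would keep the number seen with ethoxy stays open, as does how an amine on this carbon would compare. All these numbers come from a single concentration, so they say nothing about potency.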